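The source may hold more compounds than are shown below. What is called first, only, known or untested is meant among the compounds shown, and "the series" means these compounds.

Three compounds on a shared core were examined in an ADME assay on HUVEC cells (Homo sapiens) for antiproliferative activity, read by MTT assay, with a stated time of 48 h; on this read-out lower numbers stand for stronger inhibition and higher numbers for weaker inhibition. Compound 1 `N#CC1=C(N)Oc2c(c3nc4ccccc4nc3c3ccccc23)C12C(=O)N(Cc1cnnn1-c1cccc(Br)c1)c1ccccc12` carries a 3-bromophenyl on an aromatic nitrogen, and in this assay compound 1 reaches only the limit of the assay, > 50000 nM, with no number. Compound 2 `Cc1ccc(-n2nncc2CN2C(=O)C3(C(C#N)=C(N)Oc4c3c3nc5ccccc5nc3c3ccccc43)c3ccccc32)c(C)c1`, with a 2,4-dimethylphenyl in that position, also gives a limit, > 50000 nM. Compound 3 `N#CC1=C(N)Oc2c(N)cc3nc4ccccc4nc3c2C12C(=O)N(Cc1cnnn1-c1ccc(Cl)cc1)c1ccccc12`, which bears a 4-chlorophenyl on an aromatic nitrogen, gives a limit as well, > 50000 nM. Compound 3 therefore stands level with the other two values shown, because of the limit of > 50000 nM in this assay, at which 3 of the 3 values shown sit. Among the compounds with values here, the only step that can be written out, a step that the two limits leave unreadable from compound 1 to compound 2, has no readable size, since both of its ends are limits.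

Compound 4 `Cc1ccc(-n2nncc2CN2C(=O)C3(C(C#N)=C(N)Oc4c(N)cc5nc6ccccc6nc5c43)c3ccccc32)cc1Cl` differs from compound 3 in one place: 3-chloro-4-methylphenyl in place of 4-chlorophenyl on an aromatic nitrogen. Within the data shown here, no measured step joins a 4-chlorophenyl to a 3-chloro-4-methylphenyl, so the change cannot be read from the data directly. The nearest comparison is the swap of aryl groups on the same aromatic nitrogen in a step that the two limits leave unreadable from compound 1 to compound 2, which left both readings at the limit. The step expected from compound 3 to compound 4 in this assay is therefore a step that the limit leaves unreadable from compound 3 to compound 4, nothing beyond the scatter. Compound 4 is accordingly estimated at 80000 nM, in the range 40000 nM to 200000 nM, most likely reported again as a limit rather than a number.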

Compound 4, half-maximal inhibitory concentration: > 50000 nM
Compound 4: a limit, no number (the forecaster's own chance of this, stated with the estimate: 90%); the middle value lies beyond the limit too.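

In this assay compound 4 gives > 50000 nM, which is a limit and not a number. Within the data shown here, compound 3 also gives a limit, so no step between compound 3 and compound 4 can be read. The compounds shown leave open whether any of these aryl groups on the aromatic nitrogen alters the read-out, as every value shown is the same limit: the limit of > 50000 nM in this assay, at which 4 of the 4 values shown sit.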